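Two halogens change places on the aryl group

This account rests on a few compounds, and the source may have more. Where it says the series, first, only, none or still open, it means among the compounds named here.

Three measured compounds share one core and differ only in the aryl group attached to a nitrogen on an aromatic ring. Compound 1 `COc1cc(N(CC2CC2)c2ccccc2)cnc1C(=O)[C@H]1C[C@@H]1C(=O)O` carries a plain phenyl there and gives 158 nM in an assay for inhibition of leukotriene C4 synthase (Homo sapiens), read by LC-MS, with stated times of 15 min and 30 min; a higher number here means a weaker inhibitor, a lower number a stronger inhibitor. Compound 2 `COc1cc(N(CC2CC2)c2cccc(C(F)(F)F)c2)cnc1C(=O)[C@H]1C[C@@H]1C(=O)O` gives 6.42 nM in this assay, a change of a 25-fold lower number from compound 1 to compound 2 (1.39 log units; beyond the scatter). Compound 3 `COc1cc(N(CC2CC2)c2cc(Cl)ccc2F)cnc1C(=O)[C@H]1C[C@@H]1C(=O)O` gives 3.71 nM in this assay, and the step of a 43-fold lower number from compound 1 to compound 3 (1.63 log units; beyond the scatter) is the largest seen. Compound 3 thus has the lowest number of the three, but its lead over compound 2, a 1.7-fold lower number from compound 2 to compound 3 (0.24 log units; within the scatter), lies within the scatter, so the two cannot be ranked.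

Compound 4 `COc1cc(N(CC2CC2)c2ccc(F)c(Cl)c2)cnc1C(=O)[C@H]1C[C@@H]1C(=O)O` is the next step: 3-chloro-4-fluorophenyl in place of 5-chloro-2-fluorophenyl on a nitrogen on an aromatic ring. The same chlorine and fluorine stay on the ring; only their positions move. For the measured compounds named here, no measured pair tests exactly this kind of rearrangement. The closest guide is the step of a 1.7-fold lower number from compound 2 to compound 3 (0.24 log units; within the scatter), where one substituted aryl replaced another without a change beyond the scatter, while the large gains came only from adding halogens to bare phenyl, which compound 4 keeps. The expected step is therefore a 1.3-fold higher number from compound 3 to compound 4 (0.13 log units; within the scatter), none beyond the scatter. Compound 4 is estimated at 5 nM, within a range of 1.8 nM to 15 nM.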

Compound 4, half-maximal inhibitory concentration: 5.26 nM
Compound 4: middle estimate off by 1.1-fold (0.02 log units), on the low side; low and high end bracket the measured number.
By their numbers in this assay, from the lowest: compounds 3, 4 and 2 (each within the scatter of the next); then compound 1.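

Moving the same chlorine and fluorine to new places on the aryl group, with no atom gained or lost, gives a 1.4-fold higher number from compound 3 to compound 4 (0.15 log units; within the scatter) in this assay, so this pair isolates the placement of the two halogens and shows no change beyond the scatter. Compound 4 also cannot be separated from the trifluoromethyl compound (a 1.2-fold lower number from compound 2 to compound 4 (0.09 log units; within the scatter)), yet it keeps a large gain over plain phenyl (a 30-fold lower number from compound 1 to compound 4 (1.48 log units; beyond the scatter)), so on a nitrogen on an aromatic ring, 5-chloro-2-fluorophenyl, 3-chloro-4-fluorophenyl and 3-(trifluoromethyl)phenyl all sit together, well apart from the bare ring. Nothing available here accounts for this result, neither for the gain over phenyl nor for the lack of a difference between the two halogen arrangements.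

The compounds shown leave open whether a phenyl carrying only chlorine or only fluorine would match compound 4 or would fall back toward compound 1. Also open, as far as these compounds go, is whether the same range would hold with a different kind of group on this phenyl, such as an amine or a carboxylic acid.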